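Swapping the Trichlorophenyl Amide for a Pyridine

The source may report more compounds than this note shows. Statements on the series, on what has been measured and on what is new or still open speak of the compounds shown alone.

Compound 1 `Cc1ccc(S(=O)(=O)NCc2ccc(CNC(=O)c3c(Cl)cc(Cl)cc3Cl)cc2)cc1` was tested in an assay on MDA-MB-231 cells for binding affinity to C-X-C chemokine receptor type 4 (Homo sapiens), read by immunofluorescence and microscopy, with stated times of 10 min and 30 min (on this read-out higher numbers stand for an effect only at larger amounts of compound and lower numbers for an effect already at smaller amounts), where compound 1 gives 10 nM. Compound 2 `O=C(NCc1ccc(CNS(=O)(=O)c2ccccc2)cc1)c1ccccc1Cl` gives 10 nM, so compound 1 stands level with compound 2, and together they hold the lowest number of the three. Compound 3 `COc1ccc(C(=O)NCc2ccc(CNS(=O)(=O)c3ccccc3)cc2)cc1` gives 1000 nM, the highest. Among the measured compounds shown here, the one step between compounds that differ in a single place is a 100-fold higher number from compound 2 to compound 3 (2.00 log units; beyond the scatter): a ring carrying chlorine on the carbonyl carbon was exchanged for a ring without chlorine, and the number rose by a large amount.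

Compound 4 `Cc1ccc(S(=O)(=O)NCc2ccc(CNC(=O)c3cccnc3)cc2)cc1` has not yet been measured. It differs from compound 1 in one place: pyridin-3-yl in place of 2,4,6-trichlorophenyl on a carbonyl carbon. Here, too, a chlorine-bearing ring leaves the carbonyl carbon and a ring without chlorine enters, so a large rise is expected, in the direction of compound 3. The expected step is a 30-fold higher number from compound 1 to compound 4 (1.48 log units; beyond the scatter). The estimate for compound 4 is therefore 300 nM, within a range from 30 nM to 3000 nM.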

Compound 4, effective concentration (reported as EC, without a stated level of effect): > 1000 nM
Compound 4 was reported as a limit (the forecaster's own chance of this, stated with the estimate: 10%); at least 3.3-fold (0.52 log units) between middle value and limit.
By their numbers in this assay, from the lowest: compounds 1 and 2 (each within the scatter of the next); then compound 3.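

In this assay, pyridin-3-yl in place of 2,4,6-trichlorophenyl on a carbonyl carbon gives an at least 100-fold higher number from compound 1 to compound 4 (2.00 log units; beyond the scatter). This is a second pair in which a chlorine-bearing ring on that carbon gives way to a ring without chlorine and the number rises beyond the scatter, and it extends that observation from the methoxy-bearing ring of compound 3 to a ring containing nitrogen. Compound 4 is reported only as a limit, so the step gives a smallest size rather than a true one: the limit of > 1000 nM in this assay, at which 1 of the 4 values shown sits.

The compounds shown leave open whether the rise goes with losing the chlorine atoms or with gaining the ring nitrogen, and a plain phenyl on the carbonyl carbon would separate the two. They also do not tell whether a chlorine-bearing pyridine, or a phenyl ring carrying methyl or trifluoromethyl groups, would keep the low number of compound 1.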